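The source may report more compounds than this note shows. Statements on the series, on what has been measured and on what is new or still open speak of the compounds shown alone.

Of the compounds shown here, two have been measured so far in an ADME assay on 184B5 cells (Homo sapiens) for cytotoxicity, read by MTT assay, with a stated time of 72 h; on this read-out higher numbers stand for weaker inhibition of growth and lower numbers for stronger inhibition of growth. Compound 1 `COc1ccc(OC(=O)Nc2ccc([Se]C#N)cc2)cc1` carries a methoxy group on one of its aromatic rings; in this assay compound 1 gives 19200 nM, the higher of the two numbers recorded. Compound 2 `C=CCOC(=O)Nc1ccc([Se]C#N)cc1`, which replaces the whole aryl carbamate portion with an allyl carbamate, gives 9800 nM in this assay, and the gap between the two values is within the usual scatter of repeated measurements, so the numbers alone do not show that either compound inhibits growth more strongly than the other.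

Compound 3 `N#C[Se]c1ccc(NC(=O)Oc2ccc(F)cc2)cc1` has not yet been measured. It differs from compound 1 by one change: fluoro in place of methoxy on an aromatic carbon. For the measured compounds named here, no measured pair in this set shows what such an exchange does to the read-out, so nothing measured here points toward a stronger or a weaker inhibition of growth. The step from compound 1 to compound 3 is therefore expected to be small, a 1.2-fold lower number from compound 1 to compound 3 (0.08 log units; within the scatter), and within the scatter. For compound 3 the value expected in this assay is 16000 nM, with a range from 6000 nM to 40000 nM.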

Compound 3, concentration for total growth inhibition: 29500 nM
Estimate against measurement, compound 3: 1.8-fold (0.27 log units) below, within the range that was stated.
By their numbers in this assay, from the lowest: compounds 2, 1 and 3 (each within the scatter of the next, the first and the last beyond it).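

Placing fluoro in place of methoxy on an aromatic carbon, para to a large group, gives a 1.5-fold higher number from compound 1 to compound 3 (0.19 log units; within the scatter) in this assay, the first exchange at this position for which there is a measured pair. Although fluoro has fewer heavy atoms than methoxy and no hydrogen-bond acceptor, this single pair shows no change that can be told apart from the differences seen between repeated measurements, so it gives no sign that the read-out depends on which of these two groups sits at this position. No measurement shown here offers an explanation for the values of compound 1 and compound 3, or tells what either group does at this position.

From the compounds shown here alone, what a quite different group at this position would do remains open: an amine, a carboxylic acid or a longer chain such as butoxy might move the number beyond the scatter or might leave it where it is. Going by these compounds, it is also open whether the same exchange of methoxy for fluoro would give a similarly small step on a different core, since one pair cannot establish a general pattern.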